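Cytotoxicity notes on a triazole-linked lactone series

A few compounds are considered here, and "the series" means these few. Any claim that something is new, unique, unknown or untested is made for them only; others in the source may bear on it.

Measured in an ADME assay on HFF cells (Homo sapiens) for cytotoxicity, read by MTT assay, with a stated time of 72 h (on this read-out higher numbers stand for weaker inhibition and lower numbers for stronger inhibition), so far:
- compound 1 `O=C1O[C@H]([C@@H](O)Cn2cc(-c3cc(C(F)(F)F)cc(C(F)(F)F)c3)nn2)C(OCc2ccccc2)=C1OCc1ccccc1` gives 80700 nM.
- compound 2 `Cc1ccc(-c2cn(C/C=C3\OC(=O)C(OCc4ccccc4)=C3OCc3ccccc3)nn2)cc1` gives only a limit, > 100000 nM.
- compound 3 `CCCCCc1ccc(-c2cn(C[C@H](O)[C@H]3OC(=O)C(OCc4ccccc4)=C3OCc3ccccc3)nn2)cc1` gives only a limit, > 100000 nM.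

Compound 3 therefore stands at the upper edge of what this assay reports: no number, only a limit, and it is not alone in this, since (the limit of > 100000 nM in this assay, at which 2 of the 3 values shown sit). Among the compounds with values here, compound 1 is the one member of the set with a numerical value, and that value sits close to the same edge. Within the data shown here, no step between two measured compounds is available, so nothing in these three results shows how a change on the aryl group attached to the triazole moves the read-out.

The next compound, compound 4 `O=C1O[C@H]([C@@H](O)Cn2cc(-c3cc(F)cc(F)c3)nn2)C(OCc2ccccc2)=C1OCc1ccccc1`, differs from compound 3 in one place: 3,5-difluorophenyl in place of 4-pentylphenyl on an aromatic carbon. The rest of the molecule, with its hydroxyl-bearing linker and the dibenzyloxy lactone core, is unchanged. Compound 4 also shares its difluorophenyl substitution pattern with the bis(trifluoromethyl)phenyl of compound 1, which gave 80700 nM.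

With all three measured values at or near the limit, the expected step from compound 3 to compound 4 is none beyond the scatter, an at least 1.1-fold lower number from compound 3 to compound 4 (0.04 log units; that floor lies within the scatter). Compound 4 is accordingly estimated at 90000 nM in this assay, within 40000 nM to 200000 nM, with a fair chance that only a limit is reported.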

Compound 4, half-maximal inhibitory concentration: > 100000 nM
Compound 4: only a limit was reported; the forecaster's own chance of this, stated with the estimate: 55%; middle value at least 1.1-fold (0.04 log units) from the limit.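

Compound 3 and compound 4 are both reported only as limits in this assay, so the step between them cannot be read: the limit of > 100000 nM in this assay, at which 3 of the 4 values shown sit.

The compounds shown leave open whether any change of the aryl group moves this read-out at all, with numerical readings needed on both sides of such a change.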